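Tellurium for selenium in a fibroblast cytotoxicity series

This account rests on a few compounds, and the source may have more. Where it says the series, first, only, none or still open, it means among the compounds named here.

Measured compounds:
compound 1 `COc1ccc(N(CC(=O)NCCC[Te]c2ccccc2)C(=O)CNC(=O)OC(C)(C)C)cc1`, 25000 nM
compound 2 `COc1ccc(N(CC(=O)NCCC[Se]c2ccccc2)C(=O)CNC(=O)OC(C)(C)C)cc1`, >= 100000 nM
compound 3 `COc1ccc(N(CC(=O)NCCC[Se]c2ccccc2)C(=O)CCSC2=C(C)C(=O)c3ccccc3C2=O)cc1`, 24000 nM

In an ADME assay on cells (Fibroblast, Homo sapiens) for cytotoxicity, read by MTT assay, with a stated time of 24 h (a lower number here means a stronger inhibitor, a higher number a weaker inhibitor), compound 1 gives 25000 nM. Compound 2 reaches only the limit of the assay and gives no number, >= 100000 nM, and this is the limit of >= 100000 nM in this assay, at which 1 of the 3 values shown sits. Compound 3 gives 24000 nM; the values of compound 3 and compound 1 lie within the scatter of each other.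

The change a group of 7 heavy atoms (6 carbon, 1 tellurium; one six-membered aromatic ring of carbon only) in place of a group of 7 heavy atoms (6 carbon, 1 selenium; one six-membered aromatic ring of carbon only), on a saturated chain carbon, three bonds along the chain from an amide-type nitrogen made the step of an at least 4.0-fold lower number from compound 2 to compound 1 (0.60 log units; beyond the scatter). Compound 4 `COc1ccc(N(CC(=O)NCCC[Te]c2ccccc2)C(=O)CCSC2=C(C)C(=O)c3ccccc3C2=O)cc1` carries the same change on the core of compound 3, (a group of 7 heavy atoms (6 carbon, 1 tellurium; one six-membered aromatic ring of carbon only) in place of a group of 7 heavy atoms (6 carbon, 1 selenium; one six-membered aromatic ring of carbon only), on a saturated chain carbon, three bonds along the chain from an amide-type nitrogen); the difference between the two cores is not broken down here.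

From compound 3 to compound 4 the step of a 2.7-fold lower number from compound 3 to compound 4 (0.43 log units; beyond the scatter) is expected, somewhat smaller than the earlier one because compound 3 already gives 24000 nM. Compound 4 is estimated at 9000 nM, between 3000 nM and 27000 nM.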

Compound 4, half-maximal inhibitory concentration: 4000 nM
For compound 4 the middle estimate is 2.3-fold (0.35 log units) above the measured one, within the range that was stated.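

In this assay tellurium in place of selenium again gives a lower number on the core of compound 3, with a 6.0-fold lower number from compound 3 to compound 4 (0.78 log units; beyond the scatter). The change therefore points the same way on both cores shown, but two cores are too few to establish a rule for the series, and the relative size of the two steps remains unresolved: the same change on two cores in this assay, an at least 4.0-fold lower number (0.60 log units; beyond the scatter) from compound 2 to compound 1 and a 6.0-fold lower number (0.78 log units; beyond the scatter) from compound 3 to compound 4; the limit leaves it open whether they differ
Compound 2 gives only a limit, not a number, so the earlier step has no fixed size: the limit of >= 100000 nM in this assay, at which 1 of the 4 values shown sits.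
The compounds shown leave open how a sulfur atom in the same place would compare with selenium and tellurium. They also leave open whether the step would persist with a longer chain or on a core carrying an amine or a carboxylic acid.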